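Swapping an Aromatic Amine for a Flexible Chain

The source may hold more compounds than are shown below. What is called first, only, known or untested is meant among the compounds shown, and "the series" means these compounds.

Measured so far in a functional assay on MCF7 cells (Homo sapiens) for cytotoxicity, read by MTT assay, with a stated time of 72 h; on this read-out lower numbers stand for stronger inhibition and higher numbers for weaker inhibition:
- compound 1 `Nc1cccc(Nc2c(C(=O)NCc3ccc(F)cc3)nc(Br)c3cccnc23)c1` at 8000 nM
- compound 2 `N[C@H]1CC[C@H](Nc2c(C(=O)NCc3ccc(Oc4ccccc4)cc3)nc(Br)c3cccnc23)CC1` at 7900 nM

Compound 1 stands level with compound 2: the two numbers lie within the usual scatter of each other, so neither can be ranked above the other. Compound 3 `CN(C)CCCNc1c(C(=O)NCc2ccc(F)cc2)nc(Br)c2cccnc12` has 3-(dimethylamino)propyl in place of 3-aminophenyl on a nitrogen on an aromatic ring. Within the data shown here, no measured pair shows what this change does, so any expectation is loose. The expected change, a 1.6-fold lower number from compound 1 to compound 3 (0.20 log units; within the scatter), is modest, towards stronger inhibition, and may stay within the scatter. Compound 3 is estimated at 5000 nM with an expected range from 1500 nM to 16000 nM in this assay as a rough guide.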

Compound 3, half-maximal inhibitory concentration: 7000 nM
The estimate for compound 3 lay 1.4-fold (0.15 log units) below the measured number; measured number inside the range.
By their numbers in this assay, from the lowest: compounds 3, 2 and 1 (each within the scatter of the next).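

In this assay (this assay), the step (a 1.1-fold lower number from compound 1 to compound 3 (0.06 log units; within the scatter)) shows that an open chain, 3-(dimethylamino)propyl, can stand in place of the ring-bearing 3-aminophenyl on this nitrogen while compound 1 and compound 3 stay level. A group with no ring at all is therefore tolerated here as far as this read-out can tell. No supporting measurement explains why the two compounds stand level.

Open, going by these compounds, is whether a longer chain, a shorter chain or a chain carrying a carboxylic acid in place of the dimethylamino group would read differently. Also open, on these data alone, is whether a morpholine ring on the chain would move the number beyond the scatter.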